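The compounds below may be only part of what the source reports. "The series", "measured", "known", "first", "only" and "open" are said of these compounds alone.

Compound 1 `CCCCCCCCOc1nc(N)nc2c1ncn2/C=C1/CC1(CO)CO` is one of three close analogues examined in an ADME assay on BCBL1 cells (Homo sapiens) for cytotoxicity, with a stated time of 7 days; on this read-out lower numbers stand for higher toxicity in this test and higher numbers for lower toxicity in this test. In this assay compound 1 gives only a limit, > 20000 nM. Compound 3 `CSc1nc(N)nc2c1ncn2/C=C1/CC1(CO)CO` likewise gives only a limit in this assay, > 20000 nM. Within the data shown here, compound 2 `Nc1nc(NC2CCCC2)c2ncn(/C=C3/CC3(CO)CO)c2n1` is the single member with a number in this assay, 71700 nM. Because two of the three values sit at the limit of > 20000 nM in this assay, at which 2 of the 3 values shown sit, none of the steps among them can be sized: a step that the limit leaves unreadable from compound 1 to compound 2, a step that the two limits leave unreadable from compound 1 to compound 3 and a step that the limit leaves unreadable from compound 2 to compound 3 all remain unreadable. Compound 4 `Nc1nc(SCc2ccccc2)c2ncn(/C=C3/CC3(CO)CO)c2n1` differs from compound 1 by benzylsulfanyl in place of octyloxy on an aromatic carbon. Among the measured compounds shown here, the measured steps that touch the same aromatic carbon of the shared core are exactly those three unreadable ones, so they give no direction for the step to compound 4; what they do show is that every variant at this carbon so far is weakly cytotoxic at best. In this assay compound 4 is therefore expected to give 40000 nM, between 15000 nM and 120000 nM, an expected step that the limit leaves unreadable from compound 1 to compound 4 that is most likely to be hidden behind the limit again.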

Compound 4, half-maximal cytotoxic concentration: > 20000 nM
Compound 4: no number, only a limit; the forecaster's own chance of this, stated with the estimate: 60%; the middle value is on the limit's open side.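

Among these compounds, compound 4 gives only a limit in this assay, so no step linking it to compound 1, compound 2 or compound 3 can be read: the limit of > 20000 nM in this assay, at which 3 of the 4 values shown sit. The compounds shown leave open whether benzylsulfanyl, octyloxy and methylsulfanyl truly differ from one another or from cyclopentylamino in this assay.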